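This account rests on a few compounds, and the source may have more. Where it says the series, first, only, none or still open, it means among the compounds named here.

Measured compounds:
compound 1 `Cc1cc(N2CC[C@@H](C)[C@@H](N(C)c3ncnc4[nH]ccc34)C2)n2nc(SCc3ccc(Cl)cc3)nc2n1`: 18400 nM
compound 2 `Cc1cc(N2CC[C@@H](C)[C@@H](N(C)c3ncnc4[nH]ccc34)C2)n2ncnc2n1`: 11300 nM
compound 3 `Cc1cc(N2CC[C@@H](C)[C@@H](N(C)c3ncnc4[nH]ccc34)C2)n2nc(SCc3ccccc3Br)nc2n1`: 21300 nM

In a functional assay on HGC-27 cells (Homo sapiens) for inhibition, read by MTT assay, with a stated time of 72 h (on this read-out lower numbers stand for stronger inhibition and higher numbers for weaker inhibition), compound 3 gives the highest of the three numbers shown, yet the step of a 1.2-fold higher number from compound 1 to compound 3 (0.06 log units; within the scatter) and the step of a 1.9-fold higher number from compound 2 to compound 3 (0.28 log units; within the scatter) both lie within the scatter, so the three compounds are not separated. Compound 4 `Cc1cc(N2CC[C@@H](C)[C@@H](N(C)c3ncnc4[nH]ccc34)C2)n2nc(SCCc3ccccc3)nc2n1` differs from compound 3 by benzyl in place of 2-bromophenyl on a saturated chain carbon bound to a sulfur. The step that bears most directly is a 1.2-fold higher number from compound 1 to compound 3 (0.06 log units; within the scatter), an exchange of one substituted benzyl for another at the same place; the steps of a 1.6-fold lower number from compound 1 to compound 2 (0.21 log units; within the scatter) and a 1.9-fold higher number from compound 2 to compound 3 (0.28 log units; within the scatter), which remove or add the whole sulfanyl group, are also within the scatter. No step beyond the scatter is therefore expected for a 1.2-fold lower number from compound 3 to compound 4 (0.07 log units; within the scatter). Compound 4 is estimated at 18000 nM, with a range of 8000 nM to 40000 nM.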

Compound 4, half-maximal inhibitory concentration: 11800 nM
For compound 4 the middle estimate is 1.5-fold (0.18 log units) above the measured one; low and high end bracket the measured number.
By their numbers in this assay, from the lowest: compounds 2, 4, 1 and 3 (each within the scatter of the next).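

In this assay phenethylsulfanyl does not separate from hydrogen on the aromatic carbon, with a 1.0-fold higher number from compound 2 to compound 4 (0.02 log units; within the scatter) as the step. Phenethylsulfanyl also stays unresolved from both substituted benzylsulfanyl groups, through a 1.8-fold lower number from compound 3 to compound 4 (0.26 log units; within the scatter) and a 1.6-fold lower number from compound 1 to compound 4 (0.19 log units; within the scatter), so all four compounds remain one undivided set, and benzyl in place of a halogenated phenyl on the saturated chain carbon bound to a sulfur gives no step beyond the scatter. No measured evidence on hand bears on these values.

Still open, as far as these compounds go, is whether any group at this place separates from hydrogen. An amine or a carboxylic acid on the sulfur-bound chain, or a longer chain such as phenylpropyl, remains untested among the compounds shown.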